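The compounds below may be only part of what the source reports. "The series", "measured", "known", "first", "only" and "open" are said of these compounds alone.

Measured so far in an ADME assay on cells (spleen, Mus musculus, strain C57BL/6) for inhibition, read by flow cytometry and propidium iodide staining, with a stated time of 24 h, at 37 degrees C; on this read-out higher numbers stand for an effect only at larger amounts of compound and lower numbers for an effect already at smaller amounts:
- compound 1 `CC(C)(O)c1cn(CC(=O)NCc2ccccc2)nn1` gives 1600 uM
- compound 2 `O=C(O)CCc1cn(CC(=O)NCc2ccccc2)nn1` gives 1420 uM

These two compounds cannot be told apart, as compound 2 at 1420 uM lies within the scatter of compound 1. The next compound is compound 3 `Nc1ccc(-c2cn(CC(=O)NCc3ccccc3)nn2)cc1`, which carries 4-aminophenyl in place of 2-carboxyethyl on an aromatic carbon.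

Within the data shown here, only one measured step bears on this change. That step, a 1.1-fold lower number from compound 1 to compound 2 (0.05 log units; within the scatter), also swapped the group on an aromatic carbon and stayed within the scatter. Among the measured compounds shown here, it is a weak guide, however, since the entering group here brings a six-membered aromatic ring and no measured step covers such a change. A modest move towards a lower number is therefore expected, with little confidence in its size. The expected step is a 2.0-fold lower number from compound 2 to compound 3 (0.31 log units; beyond the scatter). For compound 3 the estimated value is 700 uM, with an expected range from 200 uM to 1800 uM.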

Compound 3, concentration for half-maximal effect: 1240 uM
The estimate for compound 3 lay 1.8-fold (0.25 log units) below the measured number; the measured number falls inside the stated range.
By their numbers in this assay, from the lowest: compounds 3, 2 and 1 (each within the scatter of the next).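

In this assay the change from 2-carboxyethyl to 4-aminophenyl on this aromatic carbon gives a 1.1-fold lower number from compound 2 to compound 3 (0.06 log units; within the scatter), and the change from 1-hydroxy-1-methylethyl to 4-aminophenyl gives a 1.3-fold lower number from compound 1 to compound 3 (0.11 log units; within the scatter). Among these compounds, the earlier compounds had compared only two groups without a ring, whereas these steps show that a six-membered aromatic ring of carbon only at this place also leaves all three compounds within the scatter of one another. No measurement at hand accounts for this likeness among the three groups.

Still open, as far as these compounds go, is whether a plain phenyl group, without the amine, or a longer chain ending in a carboxylic acid would read the same at this place. From the compounds shown here alone, it is also open whether any group on this aromatic carbon can move the number beyond the scatter, or whether changes elsewhere on the shared core would do so.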